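The source may report more compounds than this note shows. Statements on the series, on what has been measured and on what is new or still open speak of the compounds shown alone.

Measured so far in an ADME assay (liver) for metabolic stability, with Liver microsome (Homo sapiens) as the target, read by LC-MS, using microsomes, with a stated time of 30 min, tested at 4 uM; on this read-out higher numbers stand for a more stable compound and lower numbers for a less stable compound:

Compound 1 `Cc1nc(N2CCN(C)CC2)c2nc(-c3cccc(Cl)c3)n(C3CCOCC3)c2n1` gives 25%
Compound 2 `Cc1nc(N2CCN(C)CC2)c2nc(-c3ccccc3C(F)(F)F)n(C3CCOCC3)c2n1` gives 24%
Compound 3 `Cc1nc(N2CCN(C)CC2)c2nc(-c3ccccc3C#N)n(C3CCOCC3)c2n1` gives 20%

Compound 3 stands at 20% and is not separated from the other two compounds in this assay. The aryl changes so far have all stayed inside the scatter, including a number 1 percentage points lower from compound 1 to compound 2 (within the scatter) and a number 5 percentage points lower from compound 1 to compound 3 (within the scatter).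

Compound 4 `Cc1nc(N2CCN(C)CC2)c2nc(-c3ccccc3F)n(C3CCOCC3)c2n1` has not yet been measured. It differs from compound 3 by fluoro in place of cyano on an aromatic carbon, ortho to a large group (fluoro in place of cyano on an aromatic carbon).

The closest measured evidence is cyano in place of trifluoromethyl, which gave a number 4 percentage points lower from compound 2 to compound 3 (within the scatter). Going by the values given here, no measured compound in this set carries fluoro, so this support is indirect. Since none of the three measured steps leaves the scatter, no step beyond the scatter is expected here.

The estimated change is a number 4 percentage points higher from compound 3 to compound 4 (within the scatter). Compound 4 is expected to give 24%, with an estimated range from 14% to 36%.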

Compound 4, percent of the compound remaining: 10%
Beside the measured number, compound 4's estimate is 14 percentage points above it, and the stated range ends above it.
By their numbers in this assay, from the lowest: compounds 4, 3, 2 and 1 (each within the scatter of the next, the first and the last beyond it).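

In this assay, the aryl position now gives steps beyond the scatter: fluoro in place of trifluoromethyl gives a number 14 percentage points lower from compound 2 to compound 4 (beyond the scatter) and 2-fluorophenyl in place of 3-chlorophenyl gives a number 15 percentage points lower from compound 1 to compound 4 (beyond the scatter) in this series. Fluoro in place of cyano gives a number 10 percentage points lower from compound 3 to compound 4 (within the scatter) and so does not separate the two compounds, which means that the aryl substituent matters to this read-out only in the comparisons with compound 1 and compound 2. No measurement shown here accounts for these differences.

From the compounds shown here alone, whether an amine or a methoxy group on the same aromatic carbon would stand with compound 4 or with compound 1 remains open. Also open, going by these compounds, is whether a carboxylic acid or a longer chain elsewhere on the shared core would shift these numbers.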